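The source may hold more compounds than are shown below. What is called first, only, known or untested is meant among the compounds shown, and "the series" means these compounds.

Within the data shown here, compound 3, with the structure `COc1ccc(F)c(-c2ccc3c(NC(=O)c4ccc(N5CCCN(C)CC5)cc4)n[nH]c3c2)c1F`, stands at the low end of the numbers so far gathered. In a functional assay on SNU-16 cells (Homo sapiens) for antiproliferative activity, read by CCK-8 assay, with a stated time of 72 h (a higher number here means a weaker inhibitor, a lower number a stronger inhibitor), compound 3 gives 102 nM, the lowest number among the two that are numbers. Compound 1, with the structure `COc1ccc(F)c(-c2ccc3c(NC(=O)c4ccc(N(C)CCN(C)C)cc4)n[nH]c3c2)c1F`, gives 366 nM in this assay, and the step of a 3.6-fold lower number from compound 1 to compound 3 (0.55 log units; beyond the scatter) shows that exchanging the open-chain amine for the ring brought a gain beyond the scatter. Compound 2, with the structure `CCN1CCN(c2ccc(C(=O)Nc3n[nH]c4cc(-c5c(F)cc(F)c(OC)c5F)ccc34)cc2)CC1`, gives in this assay only a limit, > 1000 nM, and so supplies no number at all (the limit of > 1000 nM in this assay, at which 1 of the 3 values shown sits).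

Compound 4, with the structure `CCN1CCN(c2ccc(C(=O)Nc3n[nH]c4cc(-c5c(F)ccc(OC)c5F)ccc34)cc2)CC1`, differs from compound 3 in one place: 4-ethylpiperazin-1-yl in place of 4-methyl-1,4-diazepan-1-yl on an aromatic carbon. Among the measured compounds shown here, no measured step covers this exact change. For the measured compounds named here, the one step that bears on it, from compound 1 to compound 3, concerns a different pair of groups, and compound 2, which carries the same 4-ethylpiperazin-1-yl group on a different aryl, offers only a limit. The expected step is therefore uncertain, and a modest loss toward the weaker side is estimated, a 2.5-fold higher number from compound 3 to compound 4 (0.39 log units; beyond the scatter). Compound 4 is thus expected to give about 250 nM in this assay, with a likely range from 80 nM to 800 nM.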

Compound 4, half-maximal inhibitory concentration: 77.4 nM
Compound 4: middle estimate off by 3.2-fold (0.51 log units), on the high side; measured number below the stated range.
By their numbers in this assay, from the lowest: compounds 4 and 3 (each within the scatter of the next); then compound 1. At a limit, above all of these: compound 2.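

Exchanging the seven-membered 4-methyl-1,4-diazepan-1-yl ring for the six-membered 4-ethylpiperazin-1-yl ring on this aromatic carbon, para to a large group, makes no difference that can be read in this assay, with a 1.3-fold lower number from compound 3 to compound 4 (0.12 log units; within the scatter), while the open-chain amine stays apart from this ring as well, with a 4.7-fold lower number from compound 1 to compound 4 (0.67 log units; beyond the scatter). Compound 2 gives only a limit, not a number: the limit of > 1000 nM in this assay, at which 1 of the 4 values shown sits. With the 4-ethylpiperazin-1-yl ring held fixed, hydrogen in place of fluoro on the other aryl carries a large step, an at least 12-fold lower number from compound 2 to compound 4 (1.11 log units; beyond the scatter), so that aryl position counts here at least as much as the ring exchange.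

From the compounds shown here alone, whether a morpholine or a 4-methylpiperazin-1-yl ring in the same place would fit with these two rings stays open. So does whether the fluoro step holds with the 4-methyl-1,4-diazepan-1-yl ring.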